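Working notes: aryl amide exchange on the shared core

The source may hold more compounds than are shown below. What is called first, only, known or untested is meant among the compounds shown, and "the series" means these compounds.

Measured so far:
compound 1, `O=C(c1ccc(Cl)cc1)N1CC(c2nc(-c3cccc(F)c3)no2)C1`, an assay on HEK293 cells for negative allosteric modulation of metabotropic glutamate receptor 5 (Homo sapiens), read by FLIPR; a higher number here means a weaker inhibitor, a lower number a stronger inhibitor: > 10000 nM
compound 2, `O=C(c1ccccc1F)N1CC[C@H]1c1nc(-c2cccc(F)c2)no1`, this assay: 920 nM

Compound 1 stands only at a limit in this assay: the value > 10000 nM is the assay limit and not a number (the limit of > 10000 nM in this assay, at which 1 of the 2 values shown sits). Among the measured compounds shown here, compound 2 gives 920 nM in this assay, but it differs from compound 1 in more than one place, so the pair yields no single step. Compound 3, `O=C(c1ccc(F)c(F)c1)N1CC(c2nc(-c3cccc(F)c3)no2)C1`, is not yet measured; it differs from compound 1 by 3,4-difluorophenyl in place of 4-chlorophenyl on a carbonyl carbon, a 3,4-difluorophenyl in place of a 4-chlorophenyl on the carbonyl carbon. For the measured compounds named here, no measured step covers this change, and the starting point is itself a limit. The expectation for the step of a number no higher from compound 1 to compound 3 (the limit leaves the size open) is no shift beyond the scatter, in either direction. Compound 3 is therefore expected near 10000 nM, with a range from 3000 nM to 30000 nM, and with a fair chance that only a limit is reported again.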

Compound 3, half-maximal inhibitory concentration: > 10000 nM
Compound 3 gave a limit, no number; the forecaster's own chance of this, stated with the estimate: 55%; the middle value sits exactly at the limit.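

Compound 1 and compound 3 both stand at a limit, not a number, in this assay, so no step can be read between them: the limit of > 10000 nM in this assay, at which 2 of the 3 values shown sit.

Left open is whether any other aryl group on the carbonyl carbon of the core of compound 1 would give a readable value in this assay.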